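Removing the Carboxy Group of Compound 2

A few compounds are considered here, and "the series" means these few. Any claim that something is new, unique, unknown or untested is made for them only; others in the source may bear on it.

In a functional assay on OVCAR-8 cells (Homo sapiens) for antiproliferative activity (on this read-out lower numbers stand for stronger inhibition and higher numbers for weaker inhibition), compound 2 (`Cn1ncc(Cl)c1-c1cc(C(=O)N[C@@H]2CN[C@H](CC(=O)O)C[C@H]2c2ccc(Cl)c(Cl)c2)oc1Cl`) gives 5120 nM as the highest of three numbers. In the same test compound 1 (`Cn1ncc(Cl)c1-c1cc(C(=O)N[C@@H]2CN[C@H](CC(O)CO)C[C@H]2c2ccc(F)c(F)c2)oc1Cl`) gives 690 nM and compound 3 (`CNC(=O)C[C@@H]1C[C@@H](c2ccc(F)c(F)c2)[C@H](NC(=O)c2cc(-c3c(Cl)cnn3C)c(Cl)o2)CN1`) gives 800 nM. The gap from compound 2 to each of these two lies beyond the scatter.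

Compound 4 (`Cn1ncc(Cl)c1-c1cc(C(=O)N[C@@H]2CN[C@H](CCN3CCCC3)C[C@H]2c2ccc(Cl)c(Cl)c2)oc1Cl`) differs from compound 2 at one place, on a saturated chain carbon bound to a saturated ring carbon: (pyrrolidin-1-yl)methyl in place of carboxy on a saturated chain carbon bound to a saturated ring carbon so that (pyrrolidin-1-yl)methyl stands in place of carboxy.

For the measured compounds named here, the only measured step at that place is a 1.2-fold higher number from compound 1 to compound 3 (0.06 log units; within the scatter) and it stays within the scatter. It involves no carboxy group, so it offers only indirect guidance. Compounds 1 and 3 also lack carboxy and both show lower numbers than compound 2, but they differ from it elsewhere too, so the data cannot tie that gap to carboxy alone.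

A move to a lower number is still expected, and the estimated size is an 11-fold lower number from compound 2 to compound 4 (1.06 log units; beyond the scatter) in this assay as a rough guess. Compound 4 is expected at 450 nM and estimated to fall from 120 nM to 1700 nM when measured.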

Compound 4, half-maximal inhibitory concentration: 1840 nM
Compound 4: the middle estimate sits 4.1-fold (0.61 log units) below what was measured; the measured number lies above the stated range.
By their numbers in this assay, from the lowest: compounds 1 and 3 (each within the scatter of the next); then compound 4; then compound 2.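

On this assay this place on a saturated chain carbon bound to a saturated ring carbon now shows a real response, with a 2.8-fold lower number from compound 2 to compound 4 (0.44 log units; beyond the scatter) as the step, whereas the earlier 1.2-fold higher number from compound 1 to compound 3 (0.06 log units; within the scatter) did not separate its two side chains. Swapping carboxy for (pyrrolidin-1-yl)methyl thus moves the number beyond the scatter, though only modestly, and this is the first direct reading of a change that removes carboxy. Nothing measured here explains why the number moves.

The change removes carboxy and adds a five-membered non-aromatic ring in a single step, so the compounds shown cannot say which of the two matters. An aminomethyl group or a plain ethyl chain at the same place on the core of compound 2 would help tell these apart.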